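Nucleoside series: benzylamine variations at the purine nitrogen

The source may report more compounds than this note shows. Statements on the series, on what has been measured and on what is new or still open speak of the compounds shown alone.

Measured compounds so far:
Compound 1 `OC[C@H]1O[C@@H](n2cnc3c(NCc4ccccc4Cl)ncnc32)[C@H](O)[C@@H]1O` — in a functional assay on MCF cells (Homo sapiens) for antiproliferative activity, with a stated time of 72 h (on this read-out higher numbers stand for weaker inhibition and lower numbers for stronger inhibition), compound 1 gives > 166000 nM, a limit of the assay.
Compound 2 `OC[C@H]1O[C@@H](n2cnc3c(NCc4ccc(Br)cc4)ncnc32)[C@H](O)[C@@H]1O` — in this assay compound 2 gives > 166000 nM, likewise a limit.
Compound 3 `Cc1cccc(CNc2ncnc3c2ncn3[C@@H]2O[C@H](CO)[C@@H](O)[C@H]2O)c1` — in this assay compound 3 gives > 166000 nM, again only a limit.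

All three values sit at the same limit (the limit of > 166000 nM in this assay, at which 3 of the 3 values shown sit), so compound 3 stands nowhere distinct: the steps a step that the two limits leave unreadable from compound 1 to compound 2, a step that the two limits leave unreadable from compound 1 to compound 3 and a step that the two limits leave unreadable from compound 2 to compound 3 are each unreadable, since both ends are limits and no number is reported on either side.

Compound 4 `OC[C@H]1O[C@@H](n2cnc3c(NCc4ccc(F)cc4F)ncnc32)[C@H](O)[C@@H]1O` differs from compound 3 by 2,4-difluorophenyl in place of 3-methylphenyl on a saturated chain carbon bound to a nitrogen on an aromatic ring. The measured steps that bear on it are all exchanges of the aryl group on the saturated chain carbon bound to a nitrogen on an aromatic ring, and none of them moved any compound off the limit. No readable size is available, so no step beyond the scatter is expected in this assay in either direction; the expected step is a step that the limit leaves unreadable from compound 3 to compound 4. Compound 4 is therefore estimated at 200000 nM, with a range from 80000 nM to 600000 nM, most likely reported again as a limit.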

Compound 4, half-maximal inhibitory concentration: > 166000 nM
Compound 4 was reported as a limit (the forecaster's own chance of this, stated with the estimate: 85%); the middle value is on the limit's open side.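

The result for compound 4 is again only a limit, so its steps from compound 1, compound 2 and compound 3 cannot be read: the limit of > 166000 nM in this assay, at which 4 of the 4 values shown sit.

The compounds shown leave open whether any aryl exchange at this place gives a readable value in this assay.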